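Sulfonyl substituent series: expectation for a phenoxy analogue

This account rests on a few compounds, and the source may have more. Where it says the series, first, only, none or still open, it means among the compounds named here.

Compound 1 `CC1(C)C=C(n2ccccc2=O)c2cc(S(N)(=O)=O)ccc2O1` carries a primary sulfonamide on the shared core. In a functional assay with Rattus norvegicus as the target (on this read-out lower numbers stand for an effect already at smaller amounts and higher numbers for an effect only at larger amounts of compound), compound 1 gives 69.2 nM. Two measured neighbours alter only the sulfonyl substituent. Compound 2 `CC(C)NS(=O)(=O)c1ccc2c(c1)C(n1ccccc1=O)=CC(C)(C)O2` gives 676 nM in this assay, and compound 3 `CN(C)S(=O)(=O)c1ccc2c(c1)C(n1ccccc1=O)=CC(C)(C)O2` gives 16.2 nM. Compound 1 therefore stands second highest of the three numbers, between them: a 4.3-fold lower number from compound 1 to compound 3 (0.63 log units; beyond the scatter) and a 9.8-fold higher number from compound 1 to compound 2 (0.99 log units; beyond the scatter). Across the two substituted sulfonamides the gap is large: a 42-fold lower number from compound 2 to compound 3 (1.62 log units; beyond the scatter).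

Compound 4 `CC1(C)C=C(n2ccccc2=O)c2cc(S(=O)(=O)Oc3ccccc3)ccc2O1` is the unmeasured member. Relative to compound 1 the change is phenoxy in place of amino on a sulfonyl sulfur. Within the data shown here, no measured step removes the nitrogen itself, so the bearing steps are indirect. The two steps from compound 1 show that what sits on the sulfonyl sulfur moves this assay well beyond the scatter in either direction, with the bulkier isopropylamino group giving the higher number and the compact dimethylamino the lower. Phenoxy is larger than either and brings no donor, so a step toward a higher number is expected, of moderate size. The expectation for compound 4 is a 3.6-fold higher number from compound 1 to compound 4 (0.56 log units; beyond the scatter), giving an estimated 250 nM with a range from 60 nM to 1200 nM.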

Compound 4, half-maximal effective concentration: 2.51 nM
Beside the measured number, compound 4's estimate is 100-fold (2.00 log units) above it; the measured number lies below the stated range.
By their numbers in this assay, from the lowest: compound 4; then compound 3; then compound 1; then compound 2.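

In this assay, among these compounds, the nitrogen on the sulfonyl sulfur proves unnecessary for a low number: phenoxy in place of amino gives a 28-fold lower number from compound 1 to compound 4 (1.44 log units; beyond the scatter) and phenoxy in place of dimethylamino gives a 6.5-fold lower number from compound 3 to compound 4 (0.81 log units; beyond the scatter), so the lowest number belongs to the only compound here without a sulfonamide. Phenoxy in place of isopropylamino gives a 270-fold lower number from compound 2 to compound 4 (2.43 log units; beyond the scatter), which widens the span reachable at this one position and shows that a larger group on the sulfonyl sulfur does not by itself lead to a higher number, with compound 2 and compound 4 going opposite ways. Nothing among the data shown explains why these steps run as they do.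

Phenoxy changes the atom attached to the sulfur and adds the aromatic ring in a single step, so the compounds shown cannot assign the change to either part; an anilino group or a methoxy group on the sulfonyl sulfur would separate the two. Also open, from the compounds shown here alone, is how far the low number survives a chlorine or a methoxy group on the phenoxy ring.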